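Chloro in place of (methylamino)methyl on compound 2

The source may report more compounds than this note shows. Statements on the series, on what has been measured and on what is new or still open speak of the compounds shown alone.

Of the compounds shown here, three have been measured in a physicochemical assay for lipophilicity, at pH 7.4; on this read-out higher numbers stand for higher lipophilicity and lower numbers for lower lipophilicity: compound 1 (`Cc1ccc2nc(NC(=O)c3ccc(C(C)(C)C)cc3)sc2c1`) gives 5.08, compound 2 (`CNCc1ccc2nc(NC(=O)c3ccc(C(C)(C)C)cc3)cn2c1`) gives 2.4 and compound 3 (`CC(C)(O)c1ccc(C(=O)Nc2cn3cc(-n4ccnc4)ccc3n2)cc1`) gives 1.27. Compound 2 is therefore second highest of the three, with compound 3 lower and compound 1 higher, both beyond the scatter. For the measured compounds named here, no measured pair differs in one place only, so there is no direct precedent.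

Compound 4 (`CC(C)(C)c1ccc(C(=O)Nc2cn3cc(Cl)ccc3n2)cc1`) has chloro in place of (methylamino)methyl on an aromatic carbon, two atoms from the ring nitrogen (chloro in place of (methylamino)methyl on an aromatic carbon). Going by the values given here, the only guide is indirect. Compound 1 also lacks (methylamino)methyl and gives 5.08, although its core differs. Compound 3 goes against this reading, lacking that group yet giving 1.27, but it also differs at the other end of the molecule.

A rise beyond the scatter is expected in this assay, with an estimated step of a number 2.10 log units higher from compound 2 to compound 4 (beyond the scatter). The estimate for compound 4 is 4.5, within a range of 3.9 to 5.1.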

Compound 4, distribution coefficient: 4.04
Estimate against measurement, compound 4: 0.46 log units above; low and high end bracket the measured number.
By their numbers in this assay, from the lowest: compound 3; then compound 2; then compound 4; then compound 1.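

This position on the shared core now has its first direct reading in this assay: chloro in place of (methylamino)methyl on an aromatic carbon gives a number 1.64 log units higher from compound 2 to compound 4 (beyond the scatter). The read-out at this position therefore responds strongly to the group it carries, with the rest of the molecule unchanged, as 3 heavy atoms with 1 hydrogen-bond donor and 1 hydrogen-bond acceptor leave and 1 chlorine enters. Nothing measured accounts for the size of this step.

A single pair cannot separate what the departure of (methylamino)methyl contributes from what the arrival of chloro contributes; a methyl, a hydroxymethyl or a dimethylamino group at this position would help to divide the two. As far as these compounds go, whether a step of this size would recur with the core of compound 1, or with the other end of compound 3, also remains open.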